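The source may report more compounds than this note shows. Statements on the series, on what has been measured and on what is new or still open speak of the compounds shown alone.

In a functional assay on MCF7 cells (Homo sapiens) for inhibition, with a stated time of 48 h (a higher number here means a weaker inhibitor, a lower number a stronger inhibitor), compound 1 (`COc1cc(Sc2c(C)[nH]c3ccccc23)cc(OC)c1OC`) gives 46 nM and compound 2 (`COc1cc(Sc2c(C)[nH]c3ccc(Cl)cc23)cc(OC)c1OC`) gives 82 nM, while compound 3 (`COc1cc(Sc2c[nH]c3ccc(I)cc23)cc(OC)c1OC`) gives 68 nM. Compound 3 thus lies within the scatter of both others, and the three values cannot be ranked. The change to compound 4 (`COc1ccc2[nH]cc(Sc3cc(OC)c(OC)c(OC)c3)c2c1`) is methoxy in place of iodo on an aromatic carbon. Going by the values given here, only one measured step bears on it, chloro in place of hydrogen on an aromatic carbon (a 1.8-fold higher number from compound 1 to compound 2 (0.25 log units; within the scatter)), and that step stays within the scatter. Among the compounds with values here, no step with methoxy entering has been measured, so the range is kept wide. In this assay no shift beyond the scatter is expected (a 1.1-fold lower number from compound 3 to compound 4 (0.05 log units; within the scatter)). For compound 4 the estimate is 60 nM (expected range 20 nM to 180 nM).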

Compound 4, half-maximal inhibitory concentration: 22 nM
Estimate against measurement, compound 4: 2.7-fold (0.44 log units) above, and the stated range covers the measured number.
By their numbers in this assay, from the lowest: compound 4; then compounds 1, 3 and 2 (each within the scatter of the next).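

Methoxy in place of iodo gives a 3.1-fold lower number from compound 3 to compound 4 (0.49 log units; beyond the scatter), so in this assay this position responds beyond the scatter to the group it carries, which the chloro in place of hydrogen step did not show. The entering methoxy also counts one hydrogen-bond acceptor where iodo counts none, though this single pair cannot link that difference to the result. Nothing at hand explains the step.
Still open, as far as these compounds go, is whether a hydroxyl, an ethoxy group or an amine at this position would match methoxy. From the compounds shown here alone, whether methoxy gives a similar step on the core of compound 1 is also open.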